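This account rests on a few compounds, and the source may have more. Where it says the series, first, only, none or still open, it means among the compounds named here.

Measured compounds in a functional assay on MDA-MB-231 cells (Homo sapiens) for antiproliferative activity, read by MTT assay, with a stated time of 48 h; on this read-out higher numbers stand for weaker inhibition and lower numbers for stronger inhibition:

Compound 1 `NS(=O)(=O)c1ccc(Nc2ncc(F)c(Nc3nc4ccccc4s3)n2)cc1`: 22600 nM
Compound 2 `NS(=O)(=O)c1ccc(Nc2ncc(F)c(Nc3nc4ccc(Cl)cc4s3)n2)cc1`: 2790 nM

Within the data shown here, compound 2 has the lowest of the two numbers in this assay; its nearest neighbour is compound 1, and the single measured step, an 8.1-fold lower number from compound 1 to compound 2 (0.91 log units; beyond the scatter), separates them, a change beyond the scatter. Compound 3 `COc1ccc2nc(Nc3nc(Nc4ccc(S(N)(=O)=O)cc4)ncc3F)sc2c1` differs from compound 2 by methoxy in place of chloro on an aromatic carbon.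

Among the measured compounds shown here, only one measured step exists, and it bears on this change only indirectly: it shows that a substituent at this place in compound 2 gives a lower number than the bare hydrogen in compound 1, while saying nothing about a methoxy group there. The data thus support that some substituent at this place is tolerated, but not which direction the exchange of chloro for methoxy takes. A step of modest size, if any, is expected, with the number for compound 3 more likely to lie between the two measured values than outside them; the expected step is a 1.6-fold higher number from compound 2 to compound 3 (0.21 log units; within the scatter). Compound 3 is therefore estimated at 4500 nM, within a range from 1500 nM to 15000 nM.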

Compound 3, half-maximal inhibitory concentration: 26600 nM
The estimate for compound 3 lay 5.9-fold (0.77 log units) below the measured number; measured number outside the range, above it.
By their numbers in this assay, from the lowest: compound 2; then compounds 1 and 3 (each within the scatter of the next).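

Compound 3 shows that the lower number at this place does not follow from just any substituent on the aromatic carbon: in this assay the exchange of chloro for methoxy gives a 9.5-fold higher number from compound 2 to compound 3 (0.98 log units; beyond the scatter), a step beyond the scatter. Set against the bare hydrogen, methoxy gives a 1.2-fold higher number from compound 1 to compound 3 (0.07 log units; within the scatter), which lies within the scatter, so in this assay methoxy at this place cannot be told apart from hydrogen. Among these three compounds only the chloro compound stands apart, which means that the identity of the group matters here and not merely the presence of one, and nothing available explains why chloro and methoxy part in this way.

The compounds shown leave open whether chloro is unusual at this place or one of several groups that would give a low number, as fluoro, bromo, trifluoromethyl, an amine or a carboxylic acid here would help to decide. They also leave open whether a longer chain such as ethoxy would behave like methoxy, and whether the effect of chloro would carry over to a core changed elsewhere.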